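Thiomorpholine for pyrrolidine on the thiocarbonyl of compound 1

This account rests on a few compounds, and the source may have more. Where it says the series, first, only, none or still open, it means among the compounds named here.

Working notes on the series. Compound 1 `N/C(=N\NC(=S)N1CCCC1)c1ccc(F)cn1` stands highest of the two numbers in hand: in a functional assay on A-375 cells (Homo sapiens) for cytotoxicity, read by MTT assay, with a stated time of 72 h, tested at 30 uM (on this read-out lower numbers stand for less inhibition of growth and higher numbers for more inhibition of growth at the one concentration tested), compound 1 gives 83.2%. Compound 2 `Cc1cccc(/C(N)=N/NC(=S)N2CCSCC2)n1` differs from it in more than one place; in this assay compound 2 gives 73.1%, a number beyond the scatter below compound 1. Compound 3 `N/C(=N\NC(=S)N1CCSCC1)c1ccc(F)cn1` is not yet measured; it carries thiomorpholin-4-yl in place of pyrrolidin-1-yl on a thiocarbonyl carbon. Within the data shown here, no single-change step of this kind is known, so a small downward step is expected, possibly within the scatter. For compound 3 the estimate is 76%, range 62% to 88%. The expected step of a number 7.2 percentage points lower from compound 1 to compound 3 (within the scatter) is a modest fall.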

Compound 3, percent growth inhibition at one concentration: 78.7%
Beside the measured number, compound 3's estimate is 2.7 percentage points below it; measured number inside the range.
By their numbers in this assay, from the lowest: compounds 2, 3 and 1 (each within the scatter of the next, the first and the last beyond it).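

In this assay, among these compounds, thiomorpholin-4-yl in place of pyrrolidin-1-yl on a thiocarbonyl carbon gives a number 4.5 percentage points lower from compound 1 to compound 3 (within the scatter), the first single-change reading at this position. The six-membered ring with its sulfur is therefore accepted here on the core of compound 1, at the one concentration tested. Nothing in hand bears on the reason for this result.

The compounds shown leave open piperidin-1-yl and morpholin-4-yl at this place, so ring size and the sulfur atom cannot yet be told apart. From the compounds shown here alone, an open-chain dimethylamino group on the same carbon also remains open.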